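The source may report more compounds than this note shows. Statements on the series, on what has been measured and on what is new or still open speak of the compounds shown alone.

Measured compounds:

Compound 1, `Nc1nc(=O)n([C@@H]2CS[C@@H](CO)O2)cc1I`: in a functional assay on Vero cells (Chlorocebus sabaeus) for inhibition (a lower number here means a stronger inhibitor, a higher number a weaker inhibitor), compound 1 gives only a limit, > 100000 nM.
Compound 2, `Nc1nc(=O)n([C@@H]2CS[C@@H](CO)O2)cc1Br`: in this assay compound 2 gives only a limit, > 100000 nM.
Compound 3, `O=c1[nH]c(=O)n([C@@H]2CS[C@@H](CO)O2)cc1Br`: in this assay compound 3 gives only a limit, > 100000 nM.

All three measured values sit at the limit of > 100000 nM in this assay, at which 3 of the 3 values shown sit, so none of them is a number. The change from compound 2 to compound 1 is iodo in place of bromo on an aromatic carbon. Its step in this assay, a step that the two limits leave unreadable from compound 2 to compound 1, cannot be read, since both ends are limits. The difference between the core of compound 2 and the core of compound 3 is not broken down here.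

Compound 4, `O=c1[nH]c(=O)n([C@@H]2CS[C@@H](CO)O2)cc1I`, is not yet measured. It differs from compound 3 by iodo in place of bromo on an aromatic carbon. This is the same kind of change as that from compound 2 to compound 1, though the surroundings are not identical: in compound 4 the iodo enters ortho to a group of 1 heavy atom, whereas in compound 1 it enters ortho to an amino group (1 heavy atom).

Within the data shown here, for compound 4 in this assay the step from compound 3 is expected to be a step that the limit leaves unreadable from compound 3 to compound 4, because the only comparable step, a step that the two limits leave unreadable from compound 2 to compound 1, left both compounds at the limit and compound 3 itself sits at > 100000 nM. Compound 4 is therefore estimated at 150000 nM, most likely again reported only as a limit, with a range from 50000 nM to 500000 nM.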

Compound 4, half-maximal inhibitory concentration: > 100000 nM
Compound 4 ended at the assay's limit; the forecaster's own chance of this, stated with the estimate: 85%; the middle value lies beyond the limit too.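

In this assay compound 4 gives > 100000 nM, which is a limit and not a number. No new step can be read between compound 3 and compound 4, iodo in place of bromo on an aromatic carbon, because both ends are limits: the limit of > 100000 nM in this assay, at which 4 of the 4 values shown sit. The compounds shown leave open whether iodo and bromo differ at all in this assay, and how strong any of these compounds is as an inhibitor.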